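From compound 1 to compound 3: adding methoxy

A few compounds are considered here, and "the series" means these few. Any claim that something is new, unique, unknown or untested is made for them only; others in the source may bear on it.

Among the measured compounds shown here, in a physicochemical assay for lipophilicity (on this read-out higher numbers stand for higher lipophilicity and lower numbers for lower lipophilicity), compound 1 (`CCC(=O)Oc1c(OC)c(OC)c(OC(=O)CC)c2ccccc12`) gives 3.44 and stands lowest of the two numbers so far, while compound 2 (`CCC(=O)Oc1c(OC)c(OC)c(OC(=O)CC)c2cc(Cl)ccc12`) gives 4.3 on the same scale. Compound 3 (`CCC(=O)Oc1c(OC)c(OC)c(OC(=O)CC)c2c(OC)cccc12`) has not yet been measured. It departs from compound 1 through methoxy in place of hydrogen on an aromatic carbon that is, methoxy in place of hydrogen on an aromatic carbon, ortho to a fused ring and meta to a fused ring. For the measured compounds named here, only one measured step can serve as a guide: a number 0.86 log units higher from compound 1 to compound 2 (beyond the scatter) for chloro in place of hydrogen on an aromatic carbon. Going by the values given here, that step involves a different group, so it only loosely bears on this change, and no methoxy step has been measured. The expected change is a number 0.11 log units higher from compound 1 to compound 3 (within the scatter) which would be small, slightly upward and within the scatter. Compound 3 is therefore estimated at 3.55 with an expected range from 3.15 to 3.95 in this measurement.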

Compound 3, partition coefficient: 3.44
Estimate against measurement, compound 3: 0.11 log units above; the measured number falls inside the stated range.
By their numbers in this assay, from the lowest: compounds 1 and 3 (each within the scatter of the next); then compound 2.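

In this assay, methoxy in place of hydrogen on an aromatic carbon, ortho to a fused ring and meta to a fused ring, gives no change at the digits printed from compound 1 to compound 3 (within the scatter), so this replacement leaves the number where it stood. Among the compounds shown here, until now the only step on record was the chloro replacement, a number 0.86 log units higher from compound 1 to compound 2 (beyond the scatter), which lies beyond the scatter; the new step shows that a replacement of hydrogen on an aromatic carbon of this core need not do so. No measured evidence accounts for this result.

For the compounds shown here, whether methoxy would behave the same way on another aromatic carbon of the core remains open, since this is its only step. Equally open, going by these compounds, is what chloro, an amine or a carboxylic acid would do at this position.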